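This account rests on a few compounds, and the source may have more. Where it says the series, first, only, none or still open, it means among the compounds named here.

Measured so far:
compound 1 `Cc1ccc(SCc2ccc(/C=C/C(=O)Nc3ccccc3N)cc2)cc1`: 4.93%
compound 2 `Nc1ccccc1NC(=O)c1ccc(CSc2ccc(Br)cc2)cc1`: 67.7%
compound 3 `COc1ccc(SCc2ccc(C(=O)Nc3ccccc3N)cc2)cc1`: 90.1%

In a functional assay on HCT-116 cells (Homo sapiens) for inhibition, read by CCK-8 assay, with a stated time of 72 h, tested at 8 uM (on this read-out higher numbers stand for more inhibition of growth at the one concentration tested and lower numbers for less inhibition of growth), compound 1 gives 4.93%, the lowest of the three numbers. The nearest measured compound is compound 2, with 67.7%, and the furthest is compound 3, with 90.1%; both gaps lie beyond the scatter. Within the data shown here, compound 2 and compound 3 share a core in which the amide sits directly on the ring, and the one measured step between them, a number 22.4 percentage points higher from compound 2 to compound 3 (beyond the scatter), came with a change on an aromatic carbon far from the sulfur.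

Compound 4 `Nc1ccccc1NC(=O)/C=C/c1ccc(CSc2cccc(F)c2)cc1` keeps the core of compound 1, with the double bond between the ring and the amide, and differs from it only on the sulfur: 3-fluorophenyl in place of 4-methylphenyl on a sulfur. Among the measured compounds shown here, no measured step touches the group on the sulfur, and the only measured step sits on a different core, so there is no direct guide. The expectation for compound 4 in this assay is therefore a step of a number 10.1 percentage points higher from compound 1 to compound 4 (beyond the scatter), upward but uncertain, since compound 1 starts low at 4.93%. Compound 4 is estimated at 15%, within a range from 0% to 50%.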

Compound 4, percent growth inhibition at one concentration: 3.22%
Estimate against measurement, compound 4: 11.8 percentage points above; the range from low to high includes it.
By their numbers in this assay, from the lowest: compounds 4 and 1 (each within the scatter of the next); then compound 2; then compound 3.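

In this assay, replacing 4-methylphenyl with 3-fluorophenyl on the sulfur gives a number 1.7 percentage points lower from compound 1 to compound 4 (within the scatter), so this first measured change to the group on the sulfur does not separate the two groups on the core of compound 1. With compound 4 at 3.22%, this one pair shows no sign at the single concentration tested that swapping one of these substituted phenyl groups for the other alters growth inhibition on this core. No available evidence bears on the reason for this result.

On these data alone, it remains open whether a very different group on the same aromatic ring, such as an amine or a carboxylic acid, would change the number on this core. No pair shown differs only in the double bond between the ring and the amide, so the effect of that feature cannot be read.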